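The source may report more compounds than this note shows. Statements on the series, on what has been measured and on what is new or still open speak of the compounds shown alone.

Three compounds share one core and one 3-(trifluoromethoxy)phenyl group, and they differ only in the group on a saturated ring carbon: compound 1 `CN1CCN(C2CCN(c3nccc4[nH]c(-c5cccc(OC(F)(F)F)c5)nc34)CC2)CC1`, compound 2 `NCC1CCN(c2nccc3[nH]c(-c4cccc(OC(F)(F)F)c4)nc23)CC1` and compound 3 `CN1CCN(CC2CCN(c3nccc4[nH]c(-c5cccc(OC(F)(F)F)c5)nc34)CC2)CC1`. In a physicochemical assay for solubility, read by HPLC, using the shake flask method, in phosphate buffer, with a stated time of 20 h, at pH 6.5 (on this read-out higher numbers stand for higher solubility and lower numbers for lower solubility), compound 1 gives 190000 nM, compound 2 gives 200000 nM and compound 3 gives 200000 nM. Compound 3 therefore stands level with compound 2 and within the scatter of compound 1.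

Compound 4 `CN1CCN(CC2CCN(c3nccc4[nH]c(-c5cc(F)cc(C(F)(F)F)c5)nc34)CC2)CC1` keeps the side chain of compound 3 but has 3-fluoro-5-(trifluoromethyl)phenyl in place of 3-(trifluoromethoxy)phenyl on an aromatic carbon.

The measured steps are all small: a 1.1-fold higher number from compound 1 to compound 2 (0.02 log units; within the scatter), a 1.1-fold higher number from compound 1 to compound 3 (0.02 log units; within the scatter) and no change at the digits printed from compound 2 to compound 3 (within the scatter), each within the scatter. None of them alters the aromatic group, so they give no direct measure of this new change, and the range must stay wide. Starting from compound 3 at 200000 nM, no shift beyond the scatter is expected in this assay. The expected step is a 1.1-fold lower number from compound 3 to compound 4 (0.05 log units; within the scatter). The estimate for compound 4 is 180000 nM, with an expected range from 70000 nM to 260000 nM.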

Compound 4, solubility: 165000 nM
Estimate against measurement, compound 4: 1.1-fold (0.04 log units) above; the measured number falls inside the stated range.
By their numbers in this assay, from the lowest: compounds 4, 1, 2 and 3 (each within the scatter of the next).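

The earlier compounds shown here differ only in the group on a saturated ring carbon, whereas this pair tests the aromatic carbon of the five-membered ring, between two ring nitrogen atoms. In this assay the exchange of 3-(trifluoromethoxy)phenyl for 3-fluoro-5-(trifluoromethyl)phenyl gives a 1.2-fold lower number from compound 3 to compound 4 (0.08 log units; within the scatter) and so leaves the read-out within the scatter, even though the entering group has no oxygen and no hydrogen-bond acceptor. No measurement shown here offers an explanation for this result.

From the compounds shown here alone, this single pair carries the side chain of compound 3, so whether the exchange behaves alike with the side chains of compound 1 or compound 2 remains open. Also open, going by these compounds, is how an aryl group bearing an amine or a carboxylic acid would read in this assay at this position.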